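Hydroxy in place of hydrogen on a compound at the limit

This account rests on a few compounds, and the source may have more. Where it says the series, first, only, none or still open, it means among the compounds named here.

Compound 1 `O=C(CSC(=S)N[C@H]1CCOC1=O)Nc1ccccc1` stands, on the numbers shown, only at a limit rather than at a value. In a functional assay on EC9706 cells (Homo sapiens) for cytotoxicity, read by MTT assay, with a stated time of 72 h (on this read-out lower numbers stand for stronger inhibition and higher numbers for weaker inhibition), compound 1 gives > 128000 nM, which is a limit of the assay and not a number. Compound 2 `O=C(CSC(=S)N[C@H]1CCOC1=O)Nc1cccc([N+](=O)[O-])c1` carries a nitro group on the aromatic ring. In this assay compound 2 gives > 128000 nM, again a limit of the assay. The step that the two limits leave unreadable from compound 1 to compound 2 therefore cannot be sized, because both values sit at the limit of > 128000 nM in this assay, at which 2 of the 2 values shown sit.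

Compound 3 `O=C(CSC(=S)N[C@H]1CCOC1=O)Nc1ccc(O)cc1` differs from compound 1 by hydroxy in place of hydrogen on an aromatic carbon. Among the compounds with values here, the one measured step, nitro for hydrogen, is the only comparison that bears on this change, and its size is not readable. No direction can be drawn from it, and with both known values at the limit, the expectation is that compound 3 also lands at or near that limit. Compound 3 is expected to give about 150000 nM in this assay, with a range from 50000 nM to 450000 nM. The expected step is accordingly a step that the limit leaves unreadable from compound 1 to compound 3, nothing beyond the scatter.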

Compound 3, half-maximal inhibitory concentration: > 128000 nM
Compound 3: no number, only a limit; the forecaster's own chance of this, stated with the estimate: 70%; the middle value lies beyond the limit too.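

Within the data shown here, compound 3, like compound 1, stands only at a limit in this assay, so the step between the two, hydroxy in place of hydrogen, cannot be read and no new step emerges: the limit of > 128000 nM in this assay, at which 3 of the 3 values shown sit. The compounds shown leave open whether any change on the aromatic ring of the shared core gives a readable value in this assay at all.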